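This account rests on a few compounds, and the source may have more. Where it says the series, first, only, none or still open, it means among the compounds named here.

Compound 1 `O=C(NO)c1ccc(/C=C/c2ccnc(-c3cccnc3)c2)cc1`: 4550 nM
Compound 2 `O=C(NO)c1ccc(/C=C/c2cccc(-c3cccc(O)c3)c2)cc1`: 8820 nM

In a functional assay on MGC-803 cells (Homo sapiens) for antiproliferative activity, read by CellTiter-Glo, with a stated time of 72 h (on this read-out higher numbers stand for weaker inhibition and lower numbers for stronger inhibition), compound 1 gives 4550 nM and compound 2 gives 8820 nM. Compound 1 holds the lower of these two numbers, but the two lie within the usual scatter of each other, so neither stands apart from the other.

Compound 3 `O=C(NO)c1ccc(/C=C/c2ccnc(-c3ccsc3)c2)cc1` keeps the core of compound 1 and carries thiophen-3-yl in place of pyridin-3-yl on an aromatic carbon, next to the ring nitrogen (thiophen-3-yl in place of pyridin-3-yl on an aromatic carbon). Among the measured compounds shown here, no pair of measured compounds shows what a change of this kind does, so the expectation starts from compound 1 at 4550 nM. No step beyond the scatter is expected in this assay. The expected change is a 1.3-fold lower number from compound 1 to compound 3 (0.11 log units; within the scatter). In this assay the estimated value for compound 3 is 3500 nM, with an expected range from 1200 nM to 10000 nM.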

Compound 3, half-maximal inhibitory concentration: 3680 nM
For compound 3 the middle estimate is 1.1-fold (0.02 log units) below the measured one; the range from low to high includes it.
By their numbers in this assay, from the lowest: compounds 3, 1 and 2 (each within the scatter of the next, the first and the last beyond it).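

In this assay, thiophen-3-yl in place of pyridin-3-yl on this aromatic carbon, next to the ring nitrogen, gives a 1.2-fold lower number from compound 1 to compound 3 (0.09 log units; within the scatter). Among the compounds shown here, this is the first direct reading at this position: the six-membered aromatic ring with a nitrogen and the five-membered aromatic ring with a sulfur cannot be told apart here, even though the exchange alters ring size, hetero atom and heavy-atom count together. No measurement shown here offers an explanation for this result.

The compounds shown leave open whether an amine, a carboxylic acid or a saturated ring such as piperidin-4-yl on this carbon would produce a step beyond the scatter. They also leave open whether a simple hydrogen at this position would give a similar number.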